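From 4-fluorophenyl to isopropyl on a ring nitrogen

A few compounds are considered here, and "the series" means these few. Any claim that something is new, unique, unknown or untested is made for them only; others in the source may bear on it.

Compound 1 `COc1ncc(-c2ccc3c(c2)N(c2ccc(F)cc2)C(=O)CO3)cc1NS(=O)(=O)c1ccc(F)cc1`: > 40000 nM (a limit)
Compound 2 `O=C1COc2ccc(-c3cccc(NS(=O)(=O)c4ccc(F)cc4)c3)cc2N1c1ccccc1`: > 40000 nM (a limit)

In a functional assay on MCF7 cells (Homo sapiens) for antiproliferative activity, read by MTT assay, with a stated time of 72 h (a lower number here means a stronger inhibitor, a higher number a weaker inhibitor), compound 1 stands at > 40000 nM as a limit and not a number. Compound 2 likewise gives > 40000 nM as a limit. Within the data shown here, neither result is an exact reading, and no measured step between two compounds is available to show how far a single structural change can move the value.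

Among the measured compounds shown here, compound 3 `COc1ncc(-c2ccc3c(c2)N(C(C)C)C(=O)CO3)cc1NS(=O)(=O)c1ccc(F)cc1` keeps the core of compound 1 but carries isopropyl in place of 4-fluorophenyl on an amide-type nitrogen in a ring as its one change. For this swap, no step beyond the scatter is expected in this assay and compound 3 is expected to remain a weak inhibitor because of the limit of > 40000 nM in this assay, at which 2 of the 2 values shown sit, in the results so far. This expectation rests on compound 1 at > 40000 nM as a limit. The estimated change is an at least 1.3-fold lower number from compound 1 to compound 3 (0.12 log units; that floor lies within the scatter) and it is only a rough figure. For compound 3 the estimate is 30000 nM with an expected range of 10000 nM to 40000 nM and a real chance of only a limit.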

Compound 3, half-maximal inhibitory concentration: 17000 nM
Compound 3: the middle estimate sits 1.8-fold (0.25 log units) above what was measured; the range from low to high includes it.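

In this assay, putting isopropyl in place of 4-fluorophenyl on the amide-type nitrogen in a ring gives an at least 2.3-fold lower number from compound 1 to compound 3 (0.37 log units; beyond the scatter), which shows that a change at this position can move the result by more than the usual scatter. Among these compounds, compound 3, at 17000 nM, is the only one of the three compounds with an exact reading, and that number is still high, so it remains a weak inhibitor despite the step. The true size of the step could be larger than this floor, because the value of compound 1 is a limit and not a number: the limit of > 40000 nM in this assay, at which 2 of the 3 values shown sit.

This single pair cannot tell whether the lower number goes with the loss of the aromatic ring, the loss of the fluorine or the smaller group, nor whether methyl, cyclohexyl or a longer chain such as n-butyl on this nitrogen would lower it further. It also leaves open whether isopropyl would lower the number in the same way on the core of compound 2.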